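Aryloxypropoxy series: step from compound 2 to compound 3

This account rests on a few compounds, and the source may have more. Where it says the series, first, only, none or still open, it means among the compounds named here.

Measured so far:
compound 1, `NC1=NC2(CCOCC2)N(OCCCOc2ccc(F)cc2)C(N)=N1`, > 90%
compound 2, `Cc1cc(C)cc(OCCCON2C(N)=NC(N)=NC23CCOCC3)c1`, 84.3%

In an assay on isolated protein for inhibition of Dihydrofolate reductase (Homo sapiens), read by spectrophotometry, using NADPH, with stated times of 5 s and 6 min, tested at 5 uM (a lower number here means a weaker effect, a higher number a stronger effect of the compound at the concentration tested), compound 1 gives > 90%; this is a limit of the assay, not a number, as the limit of > 90% in this assay, at which 1 of the 2 values shown sits, records. In this assay compound 2 gives 84.3%. The single step shown, a number at least 5.7 percentage points lower from compound 1 to compound 2 (that floor lies within the scatter), is the change to 3,5-dimethylphenyl in place of 4-fluorophenyl on an oxygen on a saturated carbon. For the measured compounds named here, compound 2 thus stands as the only plain number in the set; the other value is a limit.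

Compound 3, `NC1=NC2(CCOCC2)N(OCCCOc2ccccc2Br)C(N)=N1`, is the next member. Its difference from compound 2 is 2-bromophenyl in place of 3,5-dimethylphenyl on an oxygen on a saturated carbon.

Going by the values given here, only the step from compound 1 to compound 2 bears on this change, and it is a floor lying within the scatter. Among the compounds with values here, an aryl exchange at the same place has so far produced no step that can be told apart from repeated measurement. For compound 3 the expected step in this assay is therefore a number 0.7 percentage points higher from compound 2 to compound 3 (within the scatter), in no direction beyond the scatter. The estimate for compound 3 in this assay is 85%, within 70% to 95%.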

Compound 3, a percentage reported as inhibition, at one concentration (the size of the read-out at that concentration, not a potency): 83.8%
The estimate for compound 3 lay 1.2 percentage points above the measured number; low and high end bracket the measured number.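

The step in this assay is a number 0.5 percentage points lower from compound 2 to compound 3 (within the scatter), the first at this place with a plain number at both ends, so 2-bromophenyl and 3,5-dimethylphenyl on this oxygen cannot be told apart, even though one aryl group is all carbon and the other holds a bromine. The second new step, a number at least 6.2 percentage points lower from compound 1 to compound 3 (that floor lies within the scatter), is again only a floor and does not separate 2-bromophenyl from 4-fluorophenyl. Compound 1 stands at a limit of the assay, not at a number: the limit of > 90% in this assay, at which 1 of the 3 values shown sits.

All the compounds shown carry a substituted phenyl at this place, so it remains open whether a carboxylic acid or an amine on that ring, or a longer chain to the ring, would change the read-out beyond the scatter. Also open, going by these compounds, is the true size of the gap between 4-fluorophenyl and the other two aryl groups, which a plain number for compound 1 in this assay would be needed to settle.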